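Swapping phenyl for cyclopropyl on a weak antiproliferative series

This account rests on a few compounds, and the source may have more. Where it says the series, first, only, none or still open, it means among the compounds named here.

Measured so far:
compound 1 `COc1ncc(-c2ccc3c(c2)N(c2ccccc2)C(=O)CO3)cc1NS(=O)(=O)c1ccc(F)cc1` with 15200 nM
compound 2 `COc1ncc(-c2ccc3c(c2)N(C2CC2)C(=O)CO3)cc1NS(=O)(=O)c1ccc(F)cc1` with 23900 nM
compound 3 `O=C1COc2ccc(-c3cnc(Cl)c(NS(=O)(=O)c4ccc(F)cc4)c3)cc2N1c1ccccc1` with 36900 nM

All three compounds were tested in a functional assay on A-375 cells (Homo sapiens) for antiproliferative activity, read by MTT assay, with a stated time of 72 h; on this read-out lower numbers stand for stronger inhibition and higher numbers for weaker inhibition. The numbers are all large, so each compound is only a weak inhibitor of cell growth in this assay.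

Compound 1 and compound 2 share a core and differ in one place: cyclopropyl in place of phenyl on an amide-type nitrogen in a ring. This change gave a 1.6-fold higher number from compound 1 to compound 2 (0.20 log units; within the scatter), a step that lies inside the usual spread of repeated measurements, so the two compounds cannot be told apart on this read-out.

Compound 3 differs from compound 1 elsewhere: chloro in place of methoxy on an aromatic carbon. Here the step was a 2.4-fold higher number from compound 1 to compound 3 (0.39 log units; beyond the scatter), a modest loss that lies just beyond the spread.

Compound 4 `O=C1COc2ccc(-c3cnc(Cl)c(NS(=O)(=O)c4ccc(F)cc4)c3)cc2N1C1CC1` has not yet been measured. It relates to compound 3 exactly as compound 2 relates to compound 1: cyclopropyl in place of phenyl on an amide-type nitrogen in a ring. The place of the change, described in the same words in both pairs, is the same, so this is the same change made on a different core.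

Among the measured compounds shown here, the only guide is the earlier pair. Because a 1.6-fold higher number from compound 1 to compound 2 (0.20 log units; within the scatter) was small, the same change on compound 3 is expected to give a step of about a 1.5-fold higher number from compound 3 to compound 4 (0.17 log units; within the scatter), with compound 4 likely landing near the top of the range seen so far, where an assay may also report only a limit. Compound 4 is therefore estimated at 55000 nM, with a plausible range from 25000 nM to 120000 nM.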

Compound 4, half-maximal inhibitory concentration: 21800 nM
The estimate for compound 4 lay 2.5-fold (0.40 log units) above the measured number; the whole stated range lies above it.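

In this assay, cyclopropyl in place of phenyl on the amide-type nitrogen in a ring gave a 1.7-fold lower number from compound 3 to compound 4 (0.23 log units; within the scatter), and chloro in place of methoxy on an aromatic carbon gave a 1.1-fold lower number from compound 2 to compound 4 (0.04 log units; within the scatter), so neither step can be told apart from the ordinary spread of repeated measurements when taken alone. Set beside its earlier counterpart, however, the change from phenyl to cyclopropyl did not carry over as a step of fixed size from one core to the other: the same change on two cores in this assay, a 1.6-fold higher number (0.20 log units; within the scatter) from compound 1 to compound 2 and a 1.7-fold lower number (0.23 log units; within the scatter) from compound 3 to compound 4, 2.7-fold (0.43 log units) apart, beyond the scatter of two such steps. The swap of methoxy for chloro shows the same mismatch, but the four compounds form one closed square, so this is a single gap seen from two sides rather than two separate findings, and it gives neither a reason for the gap nor a rule for any further core: the same change on two cores in this assay, a 2.4-fold higher number (0.39 log units; beyond the scatter) from compound 1 to compound 3 and a 1.1-fold lower number (0.04 log units; within the scatter) from compound 2 to compound 4, 2.7-fold (0.43 log units) apart, beyond the scatter of two such steps.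

As far as these compounds go, it remains open whether a methyl group or a longer chain on the amide-type nitrogen, or an amine in place of the chloro or methoxy on the aromatic carbon, would behave the same way on both cores. All four numbers are large, so these compounds also leave open whether any change at these two places can give much stronger inhibition of cell growth.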